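The source may hold more compounds than are shown below. What is called first, only, known or untested is meant among the compounds shown, and "the series" means these compounds.

Measured in a physicochemical assay for lipophilicity; on this read-out higher numbers stand for higher lipophilicity and lower numbers for lower lipophilicity:
- compound 1 `CC(C)(C)c1ccc2c(c1)c(NO)cc[n+]2[O-]`: 2.05
- compound 2 `CC(C)(C)c1ccc2c(c1)c([N+](=O)[O-])cc[n+]2[O-]`: 3.06

Compound 1 holds the lower of the two numbers in this assay. Among the compounds with values here, the only measured step is large: a number 1.01 log units higher from compound 1 to compound 2 (beyond the scatter), with nitro in place of hydroxyamino on an aromatic carbon.

Compound 3 `CCCCc1ccc2c(c1)c(NO)cc[n+]2[O-]` keeps the hydroxyamino group of compound 1 and differs elsewhere: butyl in place of tert-butyl on an aromatic carbon. The two structures have the same atoms, joined differently.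

The measured step concerns a different group, so it bears on this change only weakly and its size should not be carried over. Within the data shown here, no measured pair varies the butyl or tert-butyl group, so the data offer no direct precedent. From the compounds shown here alone, with the atoms unchanged, no step beyond the scatter is expected in this assay, and the direction stays open. The estimate therefore starts from compound 1 at 2.05. The expected change is a number 0.10 log units higher from compound 1 to compound 3 (within the scatter). For compound 3 the estimated value is 2.15, with an expected range from 1.75 to 2.55.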

Compound 3, partition coefficient: 2.1
Compound 3: middle estimate off by 0.05 log units, on the high side; the range from low to high includes it.
By their numbers in this assay, from the lowest: compounds 1 and 3 (each within the scatter of the next); then compound 2.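

In this assay, butyl in place of tert-butyl on this aromatic carbon, meta to a fused ring and para to a fused ring, gives a number 0.05 log units higher from compound 1 to compound 3 (within the scatter), so this read-out does not separate the two groups on the core of compound 1. Within the data shown here, this is the only measured pair that varies this position, whereas the earlier step, a number 1.01 log units higher from compound 1 to compound 2 (beyond the scatter), concerns the hydroxyamino group and not this place. No independent measurement available here offers an explanation for the result at this position.

It remains open whether butyl and tert-butyl would also read alike with nitro in place of hydroxyamino, as this pair is shown only with the hydroxyamino group. Also open is how far the result extends beyond these two groups, since the compounds shown do not tell how a longer chain such as hexyl, an amine or a carboxylic acid at this place would read in this assay.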